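The source may hold more compounds than are shown below. What is called first, only, known or untested is meant among the compounds shown, and "the series" means these compounds.

Three compounds that share one core and differ only in the saturated chain beyond a carbonyl carbon have been tested in a functional assay on OVCAR-5 cells (Homo sapiens) for inhibition, with a stated time of 48 h, tested at 50 uM; on this read-out lower numbers stand for less inhibition of growth and higher numbers for more inhibition of growth at the one concentration tested. Compound 1 `C=C[C@@](C)(/C=C/c1ccc(OC(=O)CCCC)cc1)CCC=C(C)C` gives 3% and compound 2 `C=C[C@@](C)(/C=C/c1ccc(OC(=O)CCCCC)cc1)CCC=C(C)C` gives 13%, and the change is a number 10 percentage points higher from compound 1 to compound 2 (within the scatter). Compound 3 `C=C[C@@](C)(/C=C/c1ccc(OC(=O)CCCCCCC)cc1)CCC=C(C)C` gives 42%, the highest of the three. The change is a number 39 percentage points higher from compound 1 to compound 3 (beyond the scatter) and, from the nearer neighbour, a number 29 percentage points higher from compound 2 to compound 3 (beyond the scatter).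

Compound 4 `C=C[C@@](C)(/C=C/c1ccc(OC(=O)CCCCCCCCCCCCCCC)cc1)CCC=C(C)C` carries a much longer chain, and the difference reads (octyl in place of hydrogen on a saturated chain carbon, seven bonds along the chain from a carbonyl carbon). All three measured steps bear on this change, since each of them also lengthens the same chain. The numbers rise along the series, although the step with the shortest extension does not clear the scatter. Within the data shown here, every measured extension is shorter than this one, however, and no measured compound shows whether the rise continues at such a length. With compound 3 at 42% as the closest reference, the step is expected to be small, a number 3 percentage points higher from compound 3 to compound 4 (within the scatter), with real room in either direction. Compound 4 is estimated at 45%, with an expected range from 12% to 80%.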

Compound 4, percent growth inhibition at one concentration: 64%
For compound 4 the middle estimate is 19 percentage points below the measured one, and the stated range covers the measured number.
By their numbers in this assay, from the lowest: compounds 1 and 2 (each within the scatter of the next); then compound 3; then compound 4.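

In this assay the octyl group, placed seven bonds along the chain from a carbonyl carbon, gives a number 22 percentage points higher from compound 3 to compound 4 (beyond the scatter) and so shows that the rise seen up to compound 3 has not levelled off or reversed at the much longer chain of compound 4. Among these compounds, the longer reach also shows in a number 51 percentage points higher from compound 2 to compound 4 (beyond the scatter) and in a number 61 percentage points higher from compound 1 to compound 4 (beyond the scatter), which places compound 4 highest of the four, and no compound goes against the order of chain length, although the first step from compound 1 to compound 2 stays within the scatter. Nothing available bears on why the longer chain goes with more inhibition of growth.

The compounds shown leave open whether the rise is steady across the wide gap between compound 3 and compound 4 or is concentrated at some intermediate chain length, and whether a still longer chain would carry it further or reverse it. They also leave open whether the chain must remain purely saturated carbon, since a chain ending in a carboxylic acid or an amine does not appear among them.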